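The source may hold more compounds than are shown below. What is called first, only, known or untested is meant among the compounds shown, and "the series" means these compounds.

Of the compounds shown here, three have been measured in a functional assay on KB cells (Homo sapiens) for cytotoxicity, read by sulforhodamine B assay; a lower number here means a stronger inhibitor, a higher number a weaker inhibitor. Compound 1 `C=C1[C@@H](OC(C)=O)C[C@@H]2[C@](C)(COC=O)[C@H](OC(C)=O)CC[C@@]2(C)[C@@H]1C[C@@H](Nc1ccc(O)cc1)C1=CCOC1=O` gives 28900 nM, the highest of the three numbers. Compound 2 `C=C1[C@@H](OC(C)=O)C[C@@H]2[C@](C)(CO[Si](C)(C)C(C)(C)C)[C@H](OC(C)=O)CC[C@@]2(C)[C@@H]1C[C@@H](Nc1cccc(F)c1)C1=CCOC1=O` gives 4560 nM, and compound 3 `C=C1CC[C@@H]2[C@](C)(CO[Si](C)(C)C(C)(C)C)[C@H](OC(C)=O)CC[C@@]2(C)[C@@H]1C/C=C1/C(=O)OC[C@H]1OC(C)=O` gives 5050 nM; both numbers lie well under that of compound 1, and both gaps are beyond the scatter. Compound 4 `C=C1[C@@H](OC(C)=O)C[C@@H]2[C@](C)(COC=O)[C@H](OC(C)=O)CC[C@@]2(C)[C@@H]1C[C@@H](Nc1ccc(C(=O)O)cc1)C1=CCOC1=O` has not yet been measured. It differs from compound 1 in one place: carboxy in place of hydroxy on an aromatic carbon. Within the data shown here, no pair of measured compounds shows this change, so the numbers give no direction for it. The step of a 1.1-fold lower number from compound 1 to compound 4 (0.05 log units; within the scatter) is therefore expected to be small, within the scatter. Compound 4 is estimated at 26000 nM, with a range from 8000 nM to 85000 nM.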

Compound 4, half-maximal inhibitory concentration: > 50000 nM
Compound 4 ended at the assay's limit; the forecaster's own chance of this, stated with the estimate: 15%; middle value at least 1.9-fold (0.28 log units) away from the limit.
By their numbers in this assay, from the lowest: compounds 2 and 3 (each within the scatter of the next); then compound 1. At a limit, above all of these: compound 4.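

In this assay compound 4 stands at a limit of the assay, not at a number: the limit of > 50000 nM in this assay, at which 1 of the 4 values shown sits. Carboxy in place of hydroxy on this aromatic carbon gives an at least 1.7-fold higher number from compound 1 to compound 4 (0.23 log units; that floor lies within the scatter), the first reading of any change at this position. The change brings no lower number, though the true size of the step stays unfixed. The compounds shown leave open how an amine or a methyl ester at this position would read in this assay, and whether either would move the number in the other direction.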